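Ester to hydrazide at the carbonyl of a pyridone core

This account rests on a few compounds, and the source may have more. Where it says the series, first, only, none or still open, it means among the compounds named here.

Measured compounds:
compound 1 `CCOC(=O)c1c(O)c2cccnc2n(-c2ccccc2)c1=O` gives 23.5% in a functional assay on the whole organism for inhibition, with Rattus norvegicus as the target, read by paw edema, at a dose of 100 mg/kg by the oral route; a higher number here means more inhibition at the dose given (going by the name of the read-out), a lower number less inhibition
compound 2 `CCCCNC(=O)c1c(O)c2cccnc2n(-c2ccccc2)c1=O` gives 12.8% in this assay

Within the data shown here, compound 1 has the higher of the two numbers; the only measured step, a number 10.7 percentage points lower from compound 1 to compound 2 (beyond the scatter), shows that replacing ethoxy by butylamino at the carbonyl carbon lowers the read-out modestly. Compound 3 `O=C(NN1CCOCC1)c1c(O)c2cccnc2n(-c2ccccc2)c1=O` carries a change at the same place: (morpholin-4-yl)amino in place of ethoxy on a carbonyl carbon. Among the measured compounds shown here, since the one comparable step was a modest drop, a drop of similar size is expected, a number 9.5 percentage points lower from compound 1 to compound 3 (within the scatter). Compound 3 is therefore estimated at 14%, within the range 2% to 30%.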

Compound 3, a percentage reported as inhibition, in the whole organism at one dose (the size of the read-out at that dose, not a potency): -8.5%
For compound 3 the middle estimate is 22.5 percentage points above the measured one, outside the stated range (below it).
By their numbers in this assay, from the lowest: compound 3; then compound 2; then compound 1.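

At this carbonyl carbon, replacing ethoxy need not cost only a little: a number 32 percentage points lower from compound 1 to compound 3 (beyond the scatter) is a large drop, and it takes the read-out in this assay below zero. What sits on the amide-type nitrogen also counts, as morpholin-4-yl in place of butyl gives a number 21.3 percentage points lower from compound 2 to compound 3 (beyond the scatter) with the rest of the molecule unchanged. Nothing available here explains either drop.

Still open, going by these compounds, is how the carboxylic acid, with hydroxyl in place of ethoxy, would read in this assay. On these data alone, a longer chain than butyl on the amide-type nitrogen is equally open.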